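A few compounds are considered here, and "the series" means these few. Any claim that something is new, unique, unknown or untested is made for them only; others in the source may bear on it.

Compound 3 `O=C(NCC1(O)CCCCCC1)c1cc(-c2ccc(CO)cn2)ccc1Cl` gives 20 mL/min/kg in an in vitro ADME assay on microsomes from liver (Homo sapiens) for metabolic stability (a higher number here means faster removal of the compound, a lower number slower removal), the lowest of the three numbers recorded there. Compound 1 `Cc1cnc(-c2ccc(Cl)c(C(=O)NCC3(O)CCCCCC3)c2)cn1` gives 36 mL/min/kg in this assay, and compound 2 `Cc1cnc(-c2ccc(Cl)c(C(=O)NCC3(O)CCCCCC3)c2)nc1` gives 53 mL/min/kg. The step of a 1.8-fold lower number from compound 1 to compound 3 (0.26 log units; within the scatter) stays inside the scatter, as does a 1.5-fold higher number from compound 1 to compound 2 (0.17 log units; within the scatter), while a 2.7-fold lower number from compound 2 to compound 3 (0.42 log units; beyond the scatter) is the only one that goes beyond it, and only modestly. Compound 4 `COc1ccc(-c2ccc(Cl)c(C(=O)NCC3(O)CCCCCC3)c2)nc1` differs from compound 3 in one place: methoxy in place of hydroxymethyl on an aromatic carbon. All three measured steps exchange the substituent on the same aromatic carbon and none moves the clearance by more than a modest amount, so the exchange of hydroxymethyl for methoxy is expected to give at most a step within the scatter in this assay, with a slight lean toward a higher number since compound 3 already sits at the lowest end. The step of a 1.4-fold higher number from compound 3 to compound 4 (0.15 log units; within the scatter) is therefore expected to be small. Compound 4 is estimated to give 28 mL/min/kg, with a likely range from 15 mL/min/kg to 50 mL/min/kg.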

Compound 4, clearance: 122 mL/min/kg
Estimate against measurement, compound 4: 4.4-fold (0.64 log units) below; measured number outside the range, above it.
By their numbers in this assay, from the lowest: compounds 3, 1 and 2 (each within the scatter of the next, the first and the last beyond it); then compound 4.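

Swapping hydroxymethyl for methoxy keeps the same atoms, joined differently, yet in this assay this change gives the largest step in the series (a 6.1-fold higher number from compound 3 to compound 4 (0.79 log units; beyond the scatter)), so this aromatic carbon is far more sensitive than the earlier exchanges there had suggested. The 5-methoxypyridin-2-yl group also stands clear of 5-methylpyrimidin-2-yl (a 2.3-fold higher number from compound 2 to compound 4 (0.36 log units; beyond the scatter)) and of 5-methylpyrazin-2-yl (a 3.4-fold higher number from compound 1 to compound 4 (0.53 log units; beyond the scatter)), which places compound 4 alone at the top of the series. No measurement offered here accounts for this jump. The compounds shown leave open how an amine, a carboxylic acid or a longer ether chain at this carbon would compare with methoxy and hydroxymethyl. They also leave open whether 5-methoxypyrimidin-2-yl or 5-methoxypyrazin-2-yl would give a similarly high number.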